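A few compounds are considered here, and "the series" means these few. Any claim that something is new, unique, unknown or untested is made for them only; others in the source may bear on it.

Compound 1, `CCN1C(=O)N(CC)C2C1N=C(SC)N2/N=C/C=C/c1ccccc1`: in a functional assay on A549 cells (Homo sapiens) for inhibition, read by MTT assay, with a stated time of 72 h (a lower number here means a stronger inhibitor, a higher number a weaker inhibitor), compound 1 gives 21400 nM.
Compound 2, `CCN1C(=O)N(CC)C2C1N=C(SC)N2/N=C/C=C/c1ccccc1[N+](=O)[O-]`: for compound 2 the result is only a limit of the assay, > 100000 nM.

Compound 2 carries a nitro group on an aromatic carbon where compound 1 carries hydrogen, and that single change already pushed the result out of the measurable range: an at least 4.6-fold higher number from compound 1 to compound 2 (0.66 log units; beyond the scatter). Compound 2 therefore stands at the weak end of what has been measured, at the limit of > 100000 nM in this assay, at which 1 of the 2 values shown sits, so its true value is not known, only that it lies past the limit.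

Compound 3, `CCSC1=NC2C(N(CC)C(=O)N2CC)N1/N=C/C=C/c1ccccc1[N+](=O)[O-]`, differs from compound 2 in one place: methyl in place of hydrogen on a saturated chain carbon bound to a sulfur. Within the data shown here, no measured pair covers this particular change; the only step seen so far, the nitro addition from compound 1 to compound 2, concerns a different part of the molecule. Nothing in the data suggests that lengthening methylsulfanyl to ethylsulfanyl would move the result far.

The expected step is a step that the limit leaves unreadable from compound 2 to compound 3, that is, no change beyond the scatter. Compound 3 is therefore expected to give about 150000 nM in this assay, somewhere between 40000 nM and 600000 nM, most likely again only as a limit.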

Compound 3, half-maximal inhibitory concentration: > 100000 nM
Compound 3 was reported as a limit; the forecaster's own chance of this, stated with the estimate: 80%; the middle value does not contradict the limit.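

Among these compounds, compound 2 and compound 3 both give only a limit in this assay, so no step between them can be read: the limit of > 100000 nM in this assay, at which 2 of the 3 values shown sit.

The compounds shown leave open whether methylsulfanyl to ethylsulfanyl changes the result at all, and what the same change does in a compound without the nitro group.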